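A few compounds are considered here, and "the series" means these few. Any claim that something is new, unique, unknown or untested is made for them only; others in the source may bear on it.

Three purine analogues were examined in a functional assay on OVCAR-8 cells (Homo sapiens) for cytotoxicity, read by sulforhodamine B assay, with a stated time of 48 h; a higher number here means that more compound is tolerated, a lower number that less compound is tolerated. Compound 1 `ClCc1ccccc1Cn1cnc2c(Cl)nc(Cl)nc21` gave 6450 nM. Compound 2 `ClCc1ccccc1Cn1cnc2c(Cl)ncnc21`, which lacks one chloro group, gave 20400 nM, and compound 3 `ClCc1cccc(Cn2cnc3c(Cl)ncnc32)c1`, which carries the same atoms joined differently, gave 79400 nM. The difference between the core of compound 2 and that of compound 3 is not broken down here.

For the measured compounds named here, the one counted change, (chloro in place of hydrogen on an aromatic carbon), produced a 3.2-fold lower number from compound 2 to compound 1 (0.50 log units; beyond the scatter). Among the three measured compounds, compound 3 showed the highest number: compared with compound 2 it lies beyond the scatter, and compared with compound 1 it lies further still.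

Compound 4 `ClCc1cccc(Cn2cnc3c(Cl)nc(Cl)nc32)c1` is not yet measured. It stands to compound 3 as compound 1 stands to compound 2, by the change (chloro in place of hydrogen on an aromatic carbon). Since the place lines of the two changes are the same word for word, this is the same change made on a differently joined core. Going by the values given here, the expectation for compound 4 rests on the only precedent available, the step of a 3.2-fold lower number from compound 2 to compound 1 (0.50 log units; beyond the scatter), applied to the value of compound 3, 79400 nM. On that basis compound 4 is expected to show a step of a 3.2-fold lower number from compound 3 to compound 4 (0.50 log units; beyond the scatter) in this assay. Among the compounds with values here, the estimate for compound 4 is therefore 25000 nM, with an expected range from 10000 nM to 60000 nM, because the single precedent a 3.2-fold lower number from compound 2 to compound 1 (0.50 log units; beyond the scatter) is modest and the cores differ in a way not quantified here.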

Compound 4, concentration lethal to 50% of the cells: 67600 nM
Beside the measured number, compound 4's estimate is 2.7-fold (0.43 log units) below it; the whole stated range lies below it.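

In this assay, for the compounds shown here, putting chloro in place of hydrogen on an aromatic carbon of the core of compound 3 gave a 1.2-fold lower number from compound 3 to compound 4 (0.07 log units; within the scatter), so on this core the change leaves no step that can be told from the usual spread of repeated measurements. The change therefore did not carry over from one core to the other at the same size, and the two steps differ by more than the scatter allows: the same change on two cores in this assay, a 3.2-fold lower number (0.50 log units; beyond the scatter) from compound 2 to compound 1 and a 1.2-fold lower number (0.07 log units; within the scatter) from compound 3 to compound 4, 2.7-fold (0.43 log units) apart, beyond the scatter of two such steps What this does not show is why the two cores part ways, or how the change would behave on any third core; two steps in one assay give no rule, only a warning that a step seen on one core of this series cannot simply be assumed on another.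

The compounds shown leave open whether another group at the same place, between two ring nitrogen atoms, such as an amine or a methoxy group, would give a step on one core and none on the other, as chloro does here. Equally open, as far as these compounds go, is whether a bromo or fluoro group there would follow chloro on both cores.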